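The source may hold more compounds than are shown below. What is called first, only, known or untested is meant among the compounds shown, and "the series" means these compounds.

- compound 1 `C=C1C(=O)[C@@]23C(=O)OC[C@]4(C(=O)CCC(C)(C)[C@H]4C=O)[C@@H]2CC[C@@H]1[C@H]3O`: 2180 nM
- compound 2 `C=C1C(=O)[C@@]23C(=O)OC[C@]4(C(=O)CCC(C)(C)[C@H]4C=O)[C@@H]2CC[C@@H]1[C@H]3OC(=O)CC`: 1310 nM

In a functional assay on K562 cells (Homo sapiens) for cytotoxicity, read by MTT assay, with a stated time of 72 h (on this read-out lower numbers stand for stronger inhibition and higher numbers for weaker inhibition), compound 1 gives 2180 nM. Going by the values given here, only one other compound has been measured, and the two values lie within the usual scatter of each other, so compound 1 stands level with compound 2 on these numbers.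

Compound 3 `C=C1C(=O)[C@@]23C(=O)OC[C@]4(C(=O)CCC(C)(C)[C@H]4C=O)[C@@H]2CC[C@@H]1[C@H]3OC(=O)c1ccc(C)cc1` has not been measured yet. It keeps the core of compound 1 and changes the hydroxy group: (4-methylphenyl)carbonyl in place of hydrogen on an oxygen on a saturated carbon. In words, this places (4-methylphenyl)carbonyl in place of hydrogen on an oxygen on a saturated carbon.

Among the compounds with values here, only one measured step bears on this change. It is the same kind of replacement, made with propanoyl at that oxygen: a 1.7-fold lower number from compound 1 to compound 2 (0.22 log units; within the scatter). That step is small, and the group it brings differs from the one in question, so it offers only a weak guide. Within the data shown here, no measured compound carries an aromatic ring in this place, which leaves the range wide.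

The expected change is slight, in the same direction as that step and probably not beyond the scatter: an estimated 1.8-fold lower number from compound 1 to compound 3 (0.26 log units; within the scatter). The estimate for compound 3 is 1200 nM, with a range of 400 nM to 3500 nM.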

Compound 3, half-maximal inhibitory concentration: 1270 nM
Estimate against measurement, compound 3: 1.1-fold (0.02 log units) below; low and high end bracket the measured number.
By their numbers in this assay, from the lowest: compounds 3, 2 and 1 (each within the scatter of the next).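

In this assay, the change from hydroxy to ((4-methylphenyl)carbonyl)oxy on this saturated carbon gives a 1.7-fold lower number from compound 1 to compound 3 (0.23 log units; within the scatter), so a group with a six-membered aromatic ring fits at this oxygen without any step beyond the scatter. The comparison of the two esters is new, and replacing ethyl with 4-methylphenyl on the carbonyl carbon gives a 1.0-fold lower number from compound 2 to compound 3 (0.01 log units; within the scatter), which means that these two very different ends of the ester cannot be told apart on this read-out. Across compounds 1, 2 and 3, then, neither adding an ester to the hydroxy group nor changing the ester from a short chain to an aromatic ring gives a difference larger than the scatter, and no measurement is available to explain this.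

As far as these compounds go, it remains open whether any group on this oxygen can shift the number beyond the scatter, for instance an acyl group carrying an amine or a carboxylic acid, a much longer chain, or a simple methyl ether in place of the ester. The compounds shown also differ only at this oxygen, so they say nothing about changes elsewhere on the shared core.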